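This account rests on a few compounds, and the source may have more. Where it says the series, first, only, none or still open, it means among the compounds named here.

Working notes on the series in a functional assay on MCF7 cells (Homo sapiens) for antiproliferative activity, read by MTT assay, with a stated time of 72 h; a higher number here means a weaker inhibitor, a lower number a stronger inhibitor: compound 1 `CCN1CCN(c2cc(C)c3cc(NC(=O)c4ccc(Br)cc4)ccc3n2)CC1` gives 5940 nM, compound 2 `CCc1ccccc1C(=O)Nc1ccc2nc(N3CCN(CC)CC3)cc(C)c2c1` gives 15800 nM and compound 3 `CCN1CCN(c2cc(C)c3cc(NC(=O)c4ccccc4Br)ccc3n2)CC1` gives 27500 nM. At the upper end of these numbers, a 1.7-fold higher number from compound 2 to compound 3 (0.24 log units; within the scatter) gives no separation, while a 4.6-fold higher number from compound 1 to compound 3 (0.67 log units; beyond the scatter) does. Next is compound 4 `CCN1CCN(c2cc(C)c3cc(NC(=O)c4cccc(Br)c4)ccc3n2)CC1`, with 3-bromophenyl in place of 2-bromophenyl on a carbonyl carbon. Within the data shown here, the closest evidence is a 4.6-fold higher number from compound 1 to compound 3 (0.67 log units; beyond the scatter), the one measured step that only relocates the bromine. In the same direction, a 2.7-fold higher number from compound 1 to compound 2 (0.42 log units; beyond the scatter) also leaves 4-bromophenyl behind. Among the measured compounds shown here, no measured compound carries 3-bromophenyl, so a modest step toward a lower number in this assay is expected, smaller than the first of these. The expected step is a 2.5-fold lower number from compound 3 to compound 4 (0.40 log units; beyond the scatter). The estimate for compound 4 is 11000 nM, with an expected range of 4500 nM to 26000 nM.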

Compound 4, half-maximal inhibitory concentration: 11600 nM
The estimate for compound 4 lay 1.1-fold (0.02 log units) below the measured number, and the stated range covers the measured number.
By their numbers in this assay, from the lowest: compounds 1, 4, 2 and 3 (each within the scatter of the next, the first and the last beyond it).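

Relocating the bromine from 2-bromophenyl to 3-bromophenyl, with the same atoms, gives a separation beyond the scatter (a 2.4-fold lower number from compound 3 to compound 4 (0.37 log units; beyond the scatter)) in this assay. The 3-bromophenyl amide is not separated from 4-bromophenyl (a 2.0-fold higher number from compound 1 to compound 4 (0.29 log units; within the scatter)) or from 2-ethylphenyl (a 1.4-fold lower number from compound 2 to compound 4 (0.13 log units; within the scatter)), so among the three bromine isomers only 2-bromophenyl stands apart from another, and the 3-bromophenyl and 4-bromophenyl pair cannot be ranked. No data at hand explain this dependence on bromine position. Still open, from the compounds shown here alone, is how an amine or a carboxylic acid in place of the bromine would read, and whether 3-ethylphenyl and 4-ethylphenyl would track their bromine counterparts.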